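A few compounds are considered here, and "the series" means these few. Any claim that something is new, unique, unknown or untested is made for them only; others in the source may bear on it.

Compound 1, with the structure `C#CCCCOC(=O)Cn1cnc2c1c(=O)n(C)c(=O)n2C`, was tested in a functional assay on A549 cells (Homo sapiens) for cytotoxicity, read by MTT assay, with a stated time of 48 h (on this read-out lower numbers stand for stronger inhibition and higher numbers for weaker inhibition), where compound 1 gives 56800 nM. That is the highest of the three numbers measured. Compound 3, `Cn1c(=O)c2c(ncn2CC(=O)NCc2cn(CC3OC(n4ccc(=O)[nH]c4=O)C4OC(C)(C)OC34)nn2)n(C)c1=O`, gives 53900 nM, which lies within the scatter of the number for compound 1. Compound 2, `CCn1c(=O)ccn(C2OC(Cn3cc(COC(=O)Cn4cnc5c4c(=O)n(C)c(=O)n5C)nn3)C(O)C2O)c1=O`, gives 2560 nM, a lower number beyond the scatter. Compound 4, `C#CCCOC(=O)Cn1cnc2c1c(=O)n(C)c(=O)n2C`, differs from compound 1 in one place: ethynyl in place of propargyl on a saturated chain carbon, two bonds along the chain from an oxygen next to a carbonyl group. Within the data shown here, no measured pair isolates such a change, so there is no direct guide. Because compound 1 sits at 56800 nM and the change removes only one chain carbon, the step of a 1.1-fold lower number from compound 1 to compound 4 (0.06 log units; within the scatter) is expected to stay within the scatter. Compound 4 is estimated to give 50000 nM, in a range from 20000 nM to 120000 nM.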

Compound 4, half-maximal inhibitory concentration: 104000 nM
Beside the measured number, compound 4's estimate is 2.1-fold (0.32 log units) below it, and the stated range covers the measured number.
By their numbers in this assay, from the lowest: compound 2; then compounds 3, 1 and 4 (each within the scatter of the next).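

In this assay there is a 1.8-fold higher number from compound 1 to compound 4 (0.26 log units; within the scatter) when ethynyl replaces propargyl, a step that stays within the scatter. This first direct comparison at this position, on a saturated chain carbon, shows that removing one chain carbon gives no readable change in cytotoxicity against these cells. No measured evidence here explains this result.

A single pair cannot show how the number responds to larger changes at this position. Going by these compounds, whether a longer chain or an amine here would give a step beyond the scatter remains open.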